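Trimming the pyrrolidine urea down to a methyl

The compounds below may be only part of what the source reports. "The series", "measured", "known", "first", "only" and "open" are said of these compounds alone.

Measured so far:
Compound 1, `O=C(CN1CCNCC1)N1CCC(NS(=O)(=O)c2cc(S(=O)(=O)c3ccccc3)ccc2C(F)(F)F)CC1`, gives 250 nM in a functional assay on U2OS cells for antagonist activity at proto-oncogene Wnt-3 (Homo sapiens), read by a luciferase reporter, with a stated time of 18 h; on this read-out lower numbers stand for an effect already at smaller amounts and higher numbers for an effect only at larger amounts of compound.
Compound 2, `CC(C)(C)NC(=O)N1CCC[C@H]1C(=O)N1CCC(NS(=O)(=O)c2cc(S(=O)(=O)c3ccccc3)ccc2C(F)(F)F)CC1`, gives 30 nM in this assay.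
Compound 3, `O=C([C@@H]1CCCN1C(=O)Nc1ccccc1)N1CCC(NS(=O)(=O)c2cc(S(=O)(=O)c3ccccc3)ccc2C(F)(F)F)CC1`, gives 310 nM in this assay.

Compound 3 has the highest number of the three. Its nearest neighbour is compound 1, whose value sits within the scatter of compound 3, so the two cannot be told apart. Its furthest neighbour is compound 2: a 10-fold higher number from compound 2 to compound 3 (1.01 log units; beyond the scatter). The other step on record runs the opposite way: an 8.3-fold lower number from compound 1 to compound 2 (0.92 log units; beyond the scatter).

Compound 4, `CN1CCC[C@H]1C(=O)N1CCC(NS(=O)(=O)c2cc(S(=O)(=O)c3ccccc3)ccc2C(F)(F)F)CC1`, carries a much smaller group on the five-membered ring: methyl in place of phenylcarbamoyl on an amine nitrogen in a ring. Neither measured step matches this change exactly. The step from compound 2 to compound 3 swapped only the group on the urea nitrogen; here the whole phenylcarbamoyl is removed. Compound 1, which has no pyrrolidine urea at all, sits close to compound 3, which suggests that losing the urea need not move the number far. The expectation for compound 4 in this assay is therefore a value near that of compound 3, a 1.2-fold lower number from compound 3 to compound 4 (0.09 log units; within the scatter), with wide uncertainty. The estimate for compound 4 is 250 nM, within 60 nM to 1000 nM.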

Compound 4, half-maximal effective concentration: 230 nM
Compound 4: middle estimate off by 1.1-fold (0.04 log units), on the high side; the range from low to high includes it.
By their numbers in this assay, from the lowest: compound 2; then compounds 4, 1 and 3 (each within the scatter of the next).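

In this assay, for the compounds shown here, the step from the phenylcarbamoyl to a methyl on the amine nitrogen in a ring is a 1.3-fold lower number from compound 3 to compound 4 (0.13 log units; within the scatter) and stays within the scatter, so at this place a group of nine heavy atoms and a single carbon cannot be told apart, something the earlier compounds could not show. The (tert-butyl)carbamoyl now stands apart from the methyl as well as from the phenylcarbamoyl, with a 7.7-fold higher number from compound 2 to compound 4 (0.88 log units; beyond the scatter) beyond the scatter, so among these three groups the low number belongs to compound 2 alone and the carbamoyl link by itself does not bring it, as compound 3 shows. With a 1.1-fold lower number from compound 1 to compound 4 (0.04 log units; within the scatter) also within the scatter, 1-methylpyrrolidin-2-yl and (piperazin-1-yl)methyl on the carbonyl carbon cannot be separated either, and no further measurement here offers an explanation for any of these numbers.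

Going by these compounds, what the tert-butyl contributes remains open, since an isopropyl or a cyclohexyl on the same urea nitrogen would show whether another alkyl group also gives a low number. An acetyl or a free amine hydrogen on the ring nitrogen would test whether the carbamoyl nitrogen is needed at all.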